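Lactam to pyrimidine on the amide of compound 3

A few compounds are considered here, and "the series" means these few. Any claim that something is new, unique, unknown or untested is made for them only; others in the source may bear on it.

Among the three measured compounds, compound 3 `O=C1CCC(C(=O)Nc2ccc(-c3onc4ccc(C(=O)O)cc34)cc2)CN1` sits second highest: in an assay for inhibition of inositol hexakisphosphate kinase 3 (Homo sapiens), read by colorimetric assay, coupled enzyme assay and malachite green, with a stated time of 120 min, in the presence of a further agent that is not named here (a higher number here means a weaker inhibitor, a lower number a stronger inhibitor), compound 3 gives 1650 nM, while compound 2 `O=C(O)c1ccc2noc(-c3ccc(N4CCCCC4)cc3)c2c1` gives 1790 nM and compound 1 `O=C(O)c1ccc2noc(-c3ccc(-c4cccnc4)cc3)c2c1` gives 610 nM. Compound 4 `O=C(O)c1ccc2noc(-c3ccc(NC(=O)c4ccncn4)cc3)c2c1` carries a group of 6 heavy atoms (4 carbon, 2 nitrogen; one six-membered aromatic ring with 2 hetero atoms) in place of a group of 7 heavy atoms (5 carbon, 1 nitrogen, 1 oxygen; one six-membered non-aromatic ring with 1 hetero atom), on a carbonyl carbon. Among the measured compounds shown here, the only measured step, a 2.9-fold higher number from compound 1 to compound 2 (0.47 log units; beyond the scatter), replaces an aromatic nitrogen ring by a saturated one at a different position, so it bears on the change only loosely; the present change runs the other way, from a saturated ring to an aromatic one, on a carbonyl carbon. He therefore expects a modest gain, a 1.7-fold lower number from compound 3 to compound 4 (0.22 log units; within the scatter), within the scatter or just beyond it. For compound 4 he estimates 1000 nM, with a range of 350 nM to 3000 nM.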

Compound 4, half-maximal inhibitory concentration: 430 nM
Beside the measured number, compound 4's estimate is 2.3-fold (0.37 log units) above it, within the range that was stated.
By their numbers in this assay, from the lowest: compounds 4 and 1 (each within the scatter of the next); then compounds 3 and 2 (each within the scatter of the next).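

On the carbonyl carbon of the amide, pyrimidin-4-yl in place of the six-membered non-aromatic ring gives a 3.8-fold lower number from compound 3 to compound 4 (0.58 log units; beyond the scatter) in this assay, so the group held there matters to this number. The same ((pyrimidin-4-yl)carbonyl)amino group gives a 4.2-fold lower number from compound 2 to compound 4 (0.62 log units; beyond the scatter) against piperidin-1-yl, while a 1.4-fold lower number from compound 1 to compound 4 (0.15 log units; within the scatter) shows it on a par with pyridin-3-yl. Nothing measured here explains the gain.

The compounds shown leave open whether the gain follows the aromatic ring or its ring nitrogens. Phenyl or pyridin-2-yl on the same carbonyl carbon would bear on that question.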